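The source may report more compounds than this note shows. Statements on the series, on what has been measured and on what is new or still open speak of the compounds shown alone.

Of the compounds shown here, three sharing one core have been tested in a functional assay on Ehrlich cells (Mus musculus) for cytotoxicity, tested at 10 ug/mL; a lower number here means a weaker effect, a higher number a stronger effect of the compound at the concentration tested. Compound 1, `COc1ccc(C2C(C#N)=C(N)N(c3cc(OC)c(OC)c(OC)c3)C3=C2C(=O)CC(C)(C)C3)cc1`, gives 0% in this assay. Compound 2, `COc1cc(N2C(N)=C(C#N)C(c3c(O)ccc4ccccc34)C3=C2CC(C)(C)CC3=O)cc(OC)c1OC`, gives 2%. Compound 3, `COc1cc(N2C(N)=C(C#N)C(c3cccs3)C3=C2CC(C)(C)CC3=O)cc(OC)c1OC`, gives 5%. Among the measured compounds shown here, the number for compound 3 is the highest of the three, but the step of a number 5 percentage points higher from compound 1 to compound 3 (within the scatter) and the step of a number 3 percentage points higher from compound 2 to compound 3 (within the scatter) both lie within the scatter, so no compound can be called stronger than another on these numbers.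

Compound 4, `COc1cc(N2C(N)=C(C#N)C(c3ccc(O)cc3)C3=C2CC(C)(C)CC3=O)cc(OC)c1OC`, has not yet been measured. It differs from compound 3 in one place: 4-hydroxyphenyl in place of thiophen-2-yl on a saturated ring carbon.

For the measured compounds named here, the steps that bear on this change are those that exchange the group on the same saturated ring carbon: a number 2 percentage points higher from compound 1 to compound 2 (within the scatter), a number 5 percentage points higher from compound 1 to compound 3 (within the scatter) and a number 3 percentage points higher from compound 2 to compound 3 (within the scatter). Each of them stayed within the scatter, whichever group stood on that carbon. A further exchange at the same place is therefore expected to give a step no larger than the scatter, in no particular direction, meaning a number 2 percentage points lower from compound 3 to compound 4 (within the scatter). The value expected for compound 4 in this assay is 3%, with a range from 0% to 12%.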

Compound 4, a percentage reported as activity, at one concentration (the size of the read-out at that concentration, not a potency): 10%
Compound 4: middle estimate off by 7 percentage points, on the low side; low and high end bracket the measured number.
By their numbers in this assay, from the lowest: compounds 1, 2, 3 and 4 (each within the scatter of the next).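

In this assay, 4-hydroxyphenyl on the saturated ring carbon gives a number 5 percentage points higher from compound 3 to compound 4 (within the scatter) when it replaces thiophen-2-yl and a number 8 percentage points higher from compound 2 to compound 4 (within the scatter) when it replaces 2-hydroxynaphthalen-1-yl, so a fourth group at this position still does not separate from the others. Among the compounds shown here, the smallest exchange so far, hydrogen in place of methyl on an oxygen on an aromatic ring, gives a number 10 percentage points higher from compound 1 to compound 4 (within the scatter) and so turns 4-methoxyphenyl into 4-hydroxyphenyl with no step that can be read as real. This adds a one-place change within the aromatic group itself to the earlier exchanges of whole groups, and it too stays within the scatter, although no measurement at hand offers a reason for any of these small differences.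

As far as these compounds go, whether an amine or a carboxylic acid in place of the hydroxyl on the phenyl ring, or a longer chain on the same saturated ring carbon, would give a step beyond the scatter remains open. Each read-out also comes from a single concentration, so the potency of these compounds remains unknown.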